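Notes on the step from compound 3 to compound 4

The compounds below may be only part of what the source reports. "The series", "measured", "known", "first", "only" and "open" are said of these compounds alone.

Values from a functional assay on MDA-MB-231 cells (Homo sapiens) for antiproliferative activity, read by MTT assay, with a stated time of 48 h (a higher number here means a weaker inhibitor, a lower number a stronger inhibitor), are as follows:
- compound 1 `C=CS(=O)(=O)N1CCN(c2ncnc3sc(-c4cccc5ncccc45)cc23)CC1` gives 21000 nM
- compound 2 `C=CS(=O)(=O)N1CCN(c2ncnc3sc(-c4cc(Br)cnc4F)cc23)CC1` gives 24100 nM
- compound 3 `CCCNC(=O)N1CCN(c2ncnc3sc(-c4ccc(N5CCN(C)CC5)cc4)cc23)CC1` gives 8330 nM

Compound 3 at 8330 nM holds the lowest number of the three, and its gaps to both others lie beyond the scatter. It also differs from them in more than one place, so those gaps cannot be tied to any single group.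

Compound 4 `CN1CCN(c2ccc(-c3cc4c(N5CCN(C(=O)Nc6cccc(F)c6)CC5)ncnc4s3)cc2)CC1` has 3-fluorophenyl in place of propyl on an amide-type nitrogen and otherwise matches compound 3. The series holds one measured single-place step, a 1.1-fold higher number from compound 1 to compound 2 (0.06 log units; within the scatter) and within the scatter. That step exchanges one aromatic group for another on an aromatic carbon, not on the amide-type nitrogen, so it bears on this change only indirectly. Among the compounds with values here, no measured compound shows an aromatic group at the nitrogen.

With so little evidence, no step beyond the scatter is expected in this assay and only a slight drop is estimated. The expected change is a 1.4-fold lower number from compound 3 to compound 4 (0.14 log units; within the scatter) with wide uncertainty in either direction.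

For compound 4 the estimated value is 6000 nM with an expected range from 2000 nM to 18000 nM for the measurement.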

Compound 4, half-maximal inhibitory concentration: 13200 nM
Compound 4: middle estimate off by 2.2-fold (0.34 log units), on the low side; the range from low to high includes it.
By their numbers in this assay, from the lowest: compounds 3, 4, 1 and 2 (each within the scatter of the next, the first and the last beyond it).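

In this assay, within the data shown here, the exchange of propyl for 3-fluorophenyl on the amide-type nitrogen gives a 1.6-fold higher number from compound 3 to compound 4 (0.20 log units; within the scatter) and is the first single-place step read at this nitrogen; the earlier compounds differed from compound 3 in more than one place. With the rest of compound 3 held fixed, the open chain and the larger six-membered aromatic ring cannot be told apart in this read-out, so for this pair the nitrogen carries either group without a step beyond the scatter. Nothing measured on these compounds accounts for the two groups reading alike.

Open at this nitrogen are unsubstituted phenyl, which would show whether the fluorine counts at all, and groups of another kind, such as a 2-aminoethyl chain, a carboxylic acid or a longer chain like hexyl. Also open, on these data alone, is whether the same exchange reads alike when the aromatic group on the shared core is another one, such as the quinolin-5-yl of compound 1.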